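Loss of the aryl hydrazone: compound 3 to compound 4

The source may hold more compounds than are shown below. What is called first, only, known or untested is meant among the compounds shown, and "the series" means these compounds.

Among the compounds with values here, compound 3 `Brc1cccc(/C=N/Nc2nc3ccccc3nc2Cc2ccccc2)c1` holds the lowest number of the three measured so far; in an assay on isolated protein for inhibition of Amine oxidase [flavin-containing] A (Homo sapiens), read by spectrophotometry (a lower number here means a stronger inhibitor, a higher number a weaker inhibitor), compound 3 gives 9.8 nM. Compound 1 `C/C(=N\Nc1nc2ccccc2nc1Cc1ccccc1)c1ccccc1` gives 79 nM in this assay, and compound 2 `C/C(=N\Nc1nc2ccccc2nc1Cc1ccccc1)c1cccs1` gives 64 nM. Compound 4 `C=NNc1nc2ccccc2nc1Cc1ccccc1` is not yet measured. The change from compound 3 to compound 4 is a group of 2 heavy atoms (1 carbon, 1 nitrogen; no ring) in place of a group of 9 heavy atoms (7 carbon, 1 nitrogen, 1 bromine; one six-membered aromatic ring of carbon only), on a nitrogen on an aromatic ring. Within the data shown here, the steps that bear on it both end at compound 3: an 8.1-fold lower number from compound 1 to compound 3 (0.91 log units; beyond the scatter) and a 6.5-fold lower number from compound 2 to compound 3 (0.81 log units; beyond the scatter). Both show that what hangs on the hydrazone nitrogen moves the number well beyond the scatter, and the ring present in compounds 1, 2 and 3 is absent in compound 4. The expectation is therefore a loss larger than either measured step, so a higher number for compound 4 is expected: a 61-fold higher number from compound 3 to compound 4 (1.79 log units; beyond the scatter). The estimate for compound 4 in this assay is 600 nM, with a range from 100 nM to 4000 nM.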

Compound 4, half-maximal inhibitory concentration: 86 nM
The estimate for compound 4 lay 7.0-fold (0.84 log units) above the measured number, and the stated range ends above it.
By their numbers in this assay, from the lowest: compound 3; then compounds 2, 1 and 4 (each within the scatter of the next).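

In this assay, the group on this nitrogen can shrink to the two-atom group of compound 4 with no change beyond the scatter against the ring-bearing compounds: the data give a 1.1-fold higher number from compound 1 to compound 4 (0.04 log units; within the scatter) and a 1.3-fold higher number from compound 2 to compound 4 (0.13 log units; within the scatter) as steps within it. Within the data shown here, an aromatic ring at this place is therefore not needed to reach the level of compounds 1 and 2, which the earlier compounds could not show. Only the bromine-bearing group of compound 3 stands apart here, with an 8.8-fold higher number from compound 3 to compound 4 (0.94 log units; beyond the scatter) beyond the scatter.

On these data alone, it remains open whether that gain rests on the bromine or on the ring carrying it; a plain phenyl group or a chlorine in place of the bromine on the same carbon would separate the two. Nothing measured here offers an explanation for these steps.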